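Benzyl for Methyl on Selenium in a Shared Core

The source may report more compounds than this note shows. Statements on the series, on what has been measured and on what is new or still open speak of the compounds shown alone.

Compound 3 `C[Se]/C(=N\C(=O)c1cnc2ccccc2c1)NC(=O)c1cnc2ccccc2c1` comes from a small set of compounds built on one shared core and tested in a functional assay on PC-3 cells (Homo sapiens) for cytotoxicity, read by MTT assay, with a stated time of 72 h; a lower number here means that less compound is tolerated, a higher number that more compound is tolerated. Compound 3 reaches only a limit of the assay in this assay, > 100000 nM. Two companions frame it. Compound 1 `CS/C(=N\C(=O)c1cccs1)NC(=O)c1cccs1`, the sulfur relative with a methyl on sulfur, likewise stops at a limit in this assay, > 100000 nM. Compound 2 `O=C(/N=C(/NC(=O)c1ccco1)[Se]Cc1ccccc1)c1ccco1`, a selenium compound carrying a benzyl on selenium together with a different acyl pair, gives a number in this assay, 84800 nM. Compound 3 thus sits at the limit of > 100000 nM in this assay, at which 2 of the 3 values shown sit, with no measured neighbour that differs from it in a single place.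

Compound 4 `O=C(/N=C(/NC(=O)c1cnc2ccccc2c1)[Se]Cc1ccccc1)c1cnc2ccccc2c1` is compound 3 with phenyl in place of hydrogen on a saturated chain carbon bound to a selenium atom, which reads methyl to benzyl when the cut is made one bond further out. Within the data shown here, no pair among the measured compounds isolates this change on its own, and compound 2 only shows that a benzyl on selenium can sit near the limit. In this assay the step is expected to be small, an at least 1.2-fold lower number from compound 3 to compound 4 (0.09 log units; that floor lies within the scatter). Compound 4 is expected to land at 80000 nM, somewhere between 30000 nM and 200000 nM.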

Compound 4, concentration lethal to 50% of the cells: > 100000 nM
Compound 4: a limit, no number; the forecaster's own chance of this, stated with the estimate: 45%; at least 1.2-fold (0.09 log units) between middle value and limit.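

In this assay compound 4 gives only a limit, > 100000 nM, as compound 3 does, so no step between compound 3 and compound 4 can be read: the limit of > 100000 nM in this assay, at which 3 of the 4 values shown sit.

The compounds shown leave open whether phenyl in place of hydrogen on a saturated chain carbon bound to a selenium atom changes the tolerated concentration at all.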